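A Chloro Substituent on the Pyridin-2-yl Group

The compounds below may be only part of what the source reports. "The series", "measured", "known", "first", "only" and "open" are said of these compounds alone.

Measured so far:
Compound 1, `CCc1cccc(NC(=O)CN2CCN(c3ccccn3)CC2)c1`: 67.9 nM
Compound 2, `O=C(CN1CCN(c2ccccn2)CC1)Nc1cccnc1`: 6410 nM

Both compounds were tested in an assay on HEK293 cells for displacement of a labelled ligand from D(4) dopamine receptor (Homo sapiens), read by scintillation counting, with a stated time of 60 min; a lower number here means a stronger inhibitor, a higher number a weaker inhibitor. Compound 1 gives the lower of the two numbers, and compound 2 stands a long way off: a 94-fold higher number from compound 1 to compound 2 (1.97 log units; beyond the scatter). That step concerns the group on the amide-type nitrogen, pyridin-3-yl in place of 3-ethylphenyl, and so it does not bear on the change examined here.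

Compound 3, `CCc1cccc(NC(=O)CN2CCN(c3ccc(Cl)cn3)CC2)c1`, keeps the 3-ethylphenyl of compound 1 and differs from it only on the pyridin-2-yl side: chloro in place of hydrogen on an aromatic carbon. Going by the values given here, no measured pair shows what such a chloro does, so there is no step to lean on. Compound 1 therefore serves as the plain anchor, and the expectation is a small shift, if any, that stays within the scatter: a 1.5-fold lower number from compound 1 to compound 3 (0.18 log units; within the scatter). The estimated value for compound 3 is 45 nM, with a range from 15 nM to 150 nM.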

Compound 3, inhibition constant: 172 nM
Estimate against measurement, compound 3: 3.8-fold (0.58 log units) below; measured number outside the range, above it.
By their numbers in this assay, from the lowest: compound 1; then compound 3; then compound 2.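

In this assay, the change from pyridin-2-yl to 5-chloropyridin-2-yl gives a 2.5-fold higher number from compound 1 to compound 3 (0.40 log units; beyond the scatter), so this position, two atoms from the ring nitrogen and para to a large group, does respond to a substituent. Going by these compounds alone, the earlier pair spoke only of the group on the amide-type nitrogen, and this modest step is the first reading from the pyridin-2-yl side, though it is much smaller than a 94-fold higher number from compound 1 to compound 2 (1.97 log units; beyond the scatter). Nothing available here explains the shift.

From the compounds shown here alone, whether a fluoro, a methyl or a methoxy on the same carbon would give a lower or a higher number stays open. Going by these compounds, it is also open whether the chloro would shift the number in the same way with the pyridin-3-yl of compound 2 on the amide-type nitrogen.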